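The source may hold more compounds than are shown below. What is called first, only, known or untested is meant among the compounds shown, and "the series" means these compounds.

Compounds measured:
compound 1, `CCOCCn1c(N2CCN(C)CC2)nc2ccccc21`: 10 nM
compound 2, `CCOCCn1c(N2CCCN(Cc3ccccc3)CC2)nc2ccccc21`: 15 nM
compound 3, `COCCCn1c(N2CCN(C)CC2)nc2ccccc21`: 860 nM

In a functional assay on ileum for inhibition of histamine H1 receptor (Cavia porcellus) (a higher number here means a weaker inhibitor, a lower number a stronger inhibitor), compound 3 gives the highest number of the three, well beyond the scatter from compound 1 and compound 2. Compound 4, `CN1CCN(c2nc3ccccc3n2CCOCCO)CC1`, has not been measured. It differs from compound 3 in one place: 2-hydroxyethoxy in place of methoxymethyl on a saturated chain carbon, two bonds along the chain from an aromatic nitrogen. Going by the values given here, the only measured step touching this place is an 86-fold higher number from compound 1 to compound 3 (1.93 log units; beyond the scatter), which shows that a change here can move the number a great deal. Compound 4 returns an ethoxy-type chain, as in compound 1, so the number for compound 4 is expected to fall back toward that of compound 1, a step of a 17-fold lower number from compound 3 to compound 4 (1.24 log units; beyond the scatter). The estimate for compound 4 is 50 nM, within 8 nM to 300 nM.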

Compound 4, half-maximal inhibitory concentration: 42 nM
Compound 4: the middle estimate sits 1.2-fold (0.08 log units) above what was measured; the measured number falls inside the stated range.
By their numbers in this assay, from the lowest: compounds 1 and 2 (each within the scatter of the next); then compound 4; then compound 3.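

In this assay the large rise seen with the 3-methoxypropyl chain is not a fixed result of changing this chain: 2-hydroxyethoxy in place of methoxymethyl gives (a 20-fold lower number from compound 3 to compound 4 (1.31 log units; beyond the scatter)). The position therefore accepts a hydroxy-bearing chain, though not at no cost: hydroxy in place of hydrogen on the ethoxy-type chain gives (a 4.2-fold higher number from compound 1 to compound 4 (0.62 log units; beyond the scatter)). Nothing available explains either step. Still open, going by these compounds, is how an amine or a carboxylic acid in place of this hydroxy would read, and whether a longer chain would keep the number low.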